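A few compounds are considered here, and "the series" means these few. Any claim that something is new, unique, unknown or untested is made for them only; others in the source may bear on it.

Measured so far:
compound 1, `NC1=NC2(CCSCC2)N(OCCCOc2ccc(Cl)cc2)C(N)=N1`: 580 nM
compound 2, `NC1=NC2(CCSCC2)N(OCCCOc2ccc(Br)cc2)C(N)=N1`: 740 nM
compound 3, `NC1=NC2(CCOCC2)N(OCCCOc2cccc(Br)c2)C(N)=N1`: 160 nM

These three compounds were tested in a functional assay on A549 cells (Homo sapiens) for antiproliferative activity, read by MTT assay, with a stated time of 72 h; on this read-out lower numbers stand for stronger inhibition and higher numbers for weaker inhibition. Compound 2 gives the highest of the three numbers. Compound 1 stands nearest to it, and the step of a 1.3-fold higher number from compound 1 to compound 2 (0.11 log units; within the scatter) is within the scatter, so the two cannot be put in order. Compound 3 stands furthest, with a number lower than that of compound 2 by a margin beyond the scatter; compound 3 also differs in its core, however, so that gap cannot be assigned to one change.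

Compound 4, `COc1ccc(OCCCON2C(N)=NC(N)=NC23CCSCC3)cc1`, has not yet been measured. It differs from compound 2 in one place: methoxy in place of bromo on an aromatic carbon. Within the data shown here, the only single-place step measured, a 1.3-fold higher number from compound 1 to compound 2 (0.11 log units; within the scatter), exchanges one halogen for another and lies within the scatter; it says little about bromo giving way to methoxy, and no measured pair shows that exchange. Compound 4 is therefore expected, in this assay, to show a step of a 1.1-fold lower number from compound 2 to compound 4 (0.02 log units; within the scatter), no more than the scatter, with wide uncertainty. The estimate for compound 4 is 700 nM, with a range from 250 nM to 2000 nM.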

Compound 4, half-maximal inhibitory concentration: 240 nM
The estimate for compound 4 lay 2.9-fold (0.46 log units) above the measured number; measured number outside the range, below it.
By their numbers in this assay, from the lowest: compounds 3 and 4 (each within the scatter of the next); then compounds 1 and 2 (each within the scatter of the next).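

In this assay, the change from 4-bromophenyl to 4-methoxyphenyl gives a 3.1-fold lower number from compound 2 to compound 4 (0.49 log units; beyond the scatter), and methoxy in place of chloro gives a 2.4-fold lower number from compound 1 to compound 4 (0.38 log units; beyond the scatter); both steps are modest but beyond the scatter. The earlier compounds shown here showed only that exchanging one halogen for the other at this aromatic carbon made no readable difference, whereas these steps show that the number does respond to the group placed there when methoxy replaces either halogen. Nothing available here accounts for this response. 

With only methoxy and two halogens at this place, the compounds shown leave open whether other groups, such as an amine, a hydroxyl or a longer ethoxy, would give a similar step. They also leave open whether methoxy would give a like step on the core of compound 3.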